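Variation of the sulfur-linked group in a pyrazolyl-amino series

A few compounds are considered here, and "the series" means these few. Any claim that something is new, unique, unknown or untested is made for them only; others in the source may bear on it.

Measured compounds:
compound 1 `Cc1cc(Nc2cc(-c3ccccc3)[nH]n2)n2nc(SCc3cccc(Br)c3)nc2n1` 8900 nM
compound 2 `Cc1cc(Nc2cc(-c3ccccc3)[nH]n2)n2nc(SCc3nc4ccccc4[nH]3)nc2n1` 4840 nM
compound 3 `Cc1cc(Nc2cc(-c3ccccc3)[nH]n2)n2nc(SCc3ccc(C(F)(F)F)cc3)nc2n1` 4240 nM

In a functional assay on PC-9 cells (Homo sapiens) for inhibition, read by MTT assay, with a stated time of 72 h (a higher number here means a weaker inhibitor, a lower number a stronger inhibitor), compound 1 gives 8900 nM, compound 2 gives 4840 nM and compound 3 gives 4240 nM. All three share one core and differ only in the group on a saturated chain carbon bound to a sulfur. Compound 3 carries the lowest number of the three: the step of a 2.1-fold lower number from compound 1 to compound 3 (0.32 log units; beyond the scatter) lies beyond the scatter, while the step of a 1.1-fold lower number from compound 2 to compound 3 (0.06 log units; within the scatter) does not, so compound 3 and compound 2 cannot be told apart. The step of a 1.8-fold lower number from compound 1 to compound 2 (0.26 log units; within the scatter) is also within the scatter. Taken together, exchanging one aromatic group for another at this position has moved the number only modestly.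

Compound 4 `Cc1cc(Nc2cc(-c3ccccc3)[nH]n2)n2nc(SCC3CC3)nc2n1` introduces a different kind of change at the same position: cyclopropyl in place of 4-(trifluoromethyl)phenyl on a saturated chain carbon bound to a sulfur. For the measured compounds named here, no measured step removes the aromatic ring here, so the three steps bear on it only by showing that this position has tolerated variation with small consequence. With a loss of the aromatic ring, a somewhat higher number than that of compound 3 is expected, though with wide uncertainty; the estimated step is a 1.7-fold higher number from compound 3 to compound 4 (0.22 log units; within the scatter). Compound 4 is therefore expected to give about 7000 nM, within a range from 3000 nM to 16000 nM.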

Compound 4, half-maximal inhibitory concentration: > 50000 nM
Compound 4 was reported as a limit; the forecaster's own chance of this, stated with the estimate: 10%; middle value at least 7.1-fold (0.85 log units) away from the limit.
By their numbers in this assay, from the lowest: compounds 3, 2 and 1 (each within the scatter of the next, the first and the last beyond it). At a limit, above all of these: compound 4.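

In this assay compound 4 is reported as a limit of the assay and not as a number: (the limit of > 50000 nM in this assay, at which 1 of the 4 values shown sits). For the compounds shown here, the tolerance seen among the earlier compounds therefore does not extend to every group at this position, and cyclopropyl on a saturated chain carbon bound to a sulfur stands clearly apart from the 4-(trifluoromethyl)phenyl group (an at least 11-fold higher number from compound 3 to compound 4 (1.07 log units; beyond the scatter)), from the 1H-benzimidazol-2-yl group (an at least 10-fold higher number from compound 2 to compound 4 (1.01 log units; beyond the scatter)) and from the 3-bromophenyl group (an at least 5.6-fold higher number from compound 1 to compound 4 (0.74 log units; beyond the scatter)). Among these four compounds, the three groups that carry an aromatic ring all give numbers far from the limit, while the one group without an aromatic ring sits at it, with no compound shown going against this split.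

The change from 4-(trifluoromethyl)benzyl to cyclopropylmethyl replaces the ring type and also lowers the heavy-atom count, so the compounds shown cannot separate the loss of the aromatic ring from the loss of size. As far as these compounds go, a cyclohexyl group, an unsubstituted benzyl group or a longer carbon chain on the sulfur would bear on that question, and an amine or a carboxylic acid at the end of such a chain remains open as well.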